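Carbamate series: replacing the chloropyridinyl with a triazolyl-fluorophenyl

A few compounds are considered here, and "the series" means these few. Any claim that something is new, unique, unknown or untested is made for them only; others in the source may bear on it.

Three compounds of the shared core carry a measured value. Compound 1 `CC1(OC(=O)N2C[C@H]3COC[C@@H](C2)[C@@H]3Oc2ncnc(Nc3c(F)cccc3F)c2F)CC1` gives 113 nM in a functional assay for agonist activity at Glucose-dependent insulinotropic receptor (Mus musculus), read by cAMP accumulation; on this read-out higher numbers stand for an effect only at larger amounts of compound and lower numbers for an effect already at smaller amounts. Compound 2 `CC1(OC(=O)N2CC3COCC(C2)C3Oc2ncnc(Nc3ccc(C#N)cc3Cl)c2F)CCC1` gives 60 nM in this assay. Compound 3 `CC1(OC(=O)N2CC3COCC(C2)C3Oc2ncnc(Nc3cccnc3Cl)c2F)CC1` gives 58 nM in this assay, the lowest number of the three, though within the scatter of both compound 2 and compound 1, so no order among them is claimed.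

Compound 4 `CC1(OC(=O)N2CC3COCC(C2)C3Oc2ncnc(Nc3ccc(-n4cncn4)cc3F)c2F)CC1` is not yet measured. It differs from compound 3 as follows: a group of 12 heavy atoms (8 carbon, 3 nitrogen, 1 fluorine; one five-membered aromatic ring with 3 hetero atoms, one six-membered aromatic ring of carbon only) in place of a group of 7 heavy atoms (5 carbon, 1 nitrogen, 1 chlorine; one six-membered aromatic ring with 1 hetero atom), on a nitrogen on an aromatic ring. Among the compounds with values here, no measured pair shows this change, so its size is unknown. Given that compound 2 with its 4-cyano-2-chlorophenyl sits at 60 nM, the step of a 1.2-fold lower number from compound 3 to compound 4 (0.06 log units; within the scatter) is expected to stay within the scatter. Compound 4 is estimated at 50 nM, within 15 nM to 160 nM.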

Compound 4, half-maximal effective concentration: 278 nM
Estimate against measurement, compound 4: 5.6-fold (0.75 log units) below, and the stated range ends below it.
By their numbers in this assay, from the lowest: compounds 3, 2 and 1 (each within the scatter of the next); then compound 4.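

At this place, on a nitrogen on an aromatic ring, the choice of group matters in this assay: the change gives a 4.8-fold higher number from compound 3 to compound 4 (0.68 log units; beyond the scatter) and thus the first separation in the series beyond the scatter. The earlier values lay within the scatter of one another and gave no sign of this. No available data bear on the cause of this step.

On these data alone, both the five-membered aromatic ring and the fluorine-bearing six-membered ring enter in one step, so their separate contributions remain open. As far as these compounds go, how a morpholine or a carboxylic acid in place of the five-membered ring would read also remains open.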